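Swapping an Aromatic Ring Tail for a Flexible Amine Chain

The source may hold more compounds than are shown below. What is called first, only, known or untested is meant among the compounds shown, and "the series" means these compounds.

Two compounds share one core and differ only in the group carried on a saturated chain carbon bound to an amide-type nitrogen. Compound 1 `CCC(NC(=O)C(CC(C)C)NC(=O)OCc1ccccc1)C(=O)C(=O)NCc1cccnc1` gives 120 nM in an assay on isolated protein (Oryctolagus cuniculus) for inhibition of Calpain-2 catalytic subunit (Homo sapiens); a higher number here means a weaker inhibitor, a lower number a stronger inhibitor. Compound 2 `CCC(NC(=O)C(CC(C)C)NC(=O)OCc1ccccc1)C(=O)C(=O)NCc1nccc2ccccc12` gives 150 nM in this assay. The step of a 1.3-fold higher number from compound 1 to compound 2 (0.10 log units; within the scatter) shows that exchanging one flat ring system for another at this position left the number essentially unchanged. Compound 2 sits with compound 1 within the scatter of a single measurement, so the two values cannot be told apart.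

Compound 3 `CCC(NC(=O)C(CC(C)C)NC(=O)OCc1ccccc1)C(=O)C(=O)NCCCN1CCCc2ccccc21` has not yet been measured. The change is 2-(1,2,3,4-tetrahydroquinolin-1-yl)ethyl in place of isoquinolin-1-yl on a saturated chain carbon bound to an amide-type nitrogen. Among the measured compounds shown here, only one measured step touches this position, namely a 1.3-fold higher number from compound 1 to compound 2 (0.10 log units; within the scatter), and it lay within the scatter. That step swapped one ring for another, whereas the new group is a chain ending in a non-aromatic ring with one hetero atom, so the earlier step is only a loose guide. The step of a 1.3-fold higher number from compound 2 to compound 3 (0.12 log units; within the scatter) is expected to be small. Compound 3 is estimated at 200 nM in this assay, with a range from 60 nM to 700 nM.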

Compound 3, inhibition constant: 200 nM
Compound 3: the middle estimate sits on the measured number at the digits printed, within the range that was stated.
By their numbers in this assay, from the lowest: compounds 1, 2 and 3 (each within the scatter of the next).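

Among the compounds shown here, compound 3 is the first case here in which the group at this position is more than one flat aromatic ring system exchanged for another: 2-(1,2,3,4-tetrahydroquinolin-1-yl)ethyl brings a chain and a six-membered non-aromatic ring with one hetero atom. Even so, this assay gives a 1.3-fold higher number from compound 2 to compound 3 (0.12 log units; within the scatter) for the exchange of isoquinolin-1-yl, and a 1.7-fold higher number from compound 1 to compound 3 (0.22 log units; within the scatter) for the exchange of pyridin-3-yl, so the number stays within the scatter against both earlier compounds. The position on a saturated chain carbon bound to an amide-type nitrogen therefore accepts an aromatic ring of one or two rings and a chain-linked group with a partly non-aromatic ring system with no measurable shift, although nothing shown here gives any reason for this.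

From the compounds shown here alone, all three groups still contain an aromatic ring, so it remains open whether a plain alkyl chain, or a chain ending in a primary amine or a carboxylic acid, would keep the number in this range. The three compounds also share one core, which leaves open whether the same indifference to the group at this position would hold on a different core.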